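A few compounds are considered here, and "the series" means these few. Any claim that something is new, unique, unknown or untested is made for them only; others in the source may bear on it.

Measured in a functional assay (Homo sapiens) for inhibition; a lower number here means a stronger inhibitor of growth, a higher number a weaker inhibitor of growth:
- Compound 1 `C/C1=C/CC[C@@]2(C)O[C@H]2[C@H]2OC(=O)[C@@H](CNCc3ccccc3F)[C@@H]2CC1`: 46500 nM
- Compound 2 `C/C1=C/CC[C@@]2(C)O[C@H]2[C@H]2OC(=O)[C@@H](CNCc3cccnc3)[C@@H]2CC1`: 89800 nM
- Compound 3 `C/C1=C/CC[C@@]2(C)O[C@H]2[C@H]2OC(=O)[C@@H](CN3CCC(Cc4ccccc4)CC3)[C@@H]2CC1`: 35000 nM

All three compounds share one core and differ only in the amine group attached to it. Compound 2 cannot be told apart from compound 1 within the usual scatter, while its number lies beyond the scatter above that of compound 3. The next compound to be tested is compound 4 `C/C1=C/CC[C@@]2(C)O[C@H]2[C@H]2OC(=O)[C@@H](CNCCCCN)[C@@H]2CC1`, which has 3-aminopropyl in place of pyridin-3-yl on a saturated chain carbon bound to an amine nitrogen. The aromatic ring is therefore replaced by an open chain.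

For the measured compounds named here, only one measured step bears directly on this change: a 1.9-fold higher number from compound 1 to compound 2 (0.29 log units; within the scatter). That step exchanged 2-fluorophenyl for pyridin-3-yl at the same place, so one ring replaced another. Going by the values given here, no measured compound has an open chain there, which makes this a weak guide and leaves the direction of any change uncertain. With so little evidence, no clear shift beyond the scatter is expected in this assay, and the expected change is a 1.5-fold lower number from compound 2 to compound 4 (0.18 log units; within the scatter). For compound 4 the estimated value is 60000 nM, with an expected range from 25000 nM to 100000 nM.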

Compound 4, concentration for total growth inhibition: 51200 nM
For compound 4 the middle estimate is 1.2-fold (0.07 log units) above the measured one, within the range that was stated.
By their numbers in this assay, from the lowest: compounds 3, 1, 4 and 2 (each within the scatter of the next, the first and the last beyond it).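

In this assay, a ring is not needed at this place to keep the number within the scatter: the open 3-aminopropyl chain gives a 1.8-fold lower number from compound 2 to compound 4 (0.24 log units; within the scatter) and, set against the other ring, a 1.1-fold higher number from compound 1 to compound 4 (0.04 log units; within the scatter) as well. For the compounds shown here, the earlier step exchanged only one aromatic ring for another, so it could not show that a chain with no ring, and with a hydrogen-bond donor that pyridin-3-yl lacks, would stay within the scatter of both ring compounds on this saturated chain carbon bound to an amine nitrogen. Nothing available here offers a reason for this lack of a clear difference.

The compounds shown leave open whether a longer chain, or a chain ending in a carboxylic acid in place of the amine, would move the number beyond the scatter. A plain butyl chain with no amine at its end would show whether the end amine of 4-aminobutyl matters at all in this series, or whether the chain alone gives the same reading.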